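This account rests on a few compounds, and the source may have more. Where it says the series, first, only, none or still open, it means among the compounds named here.

Compound 1 `CC(C(=O)NCc1ccc(C(F)(F)F)nc1Nc1ccccc1)c1ccc(NS(C)(=O)=O)c(F)c1` carries an anilino group on the shared core. In a functional assay on CHO-K1 cells for antagonist activity at transient receptor potential cation channel subfamily V member 1 (Homo sapiens), read by FLIPR (a lower number here means a stronger inhibitor, a higher number a weaker inhibitor), compound 1 gives 59.6 nM, the highest of the two numbers measured in this set. Compound 2 `CC(C(=O)NCc1ccc(C(F)(F)F)nc1NCc1cccnc1)c1ccc(NS(C)(=O)=O)c(F)c1`, with a pyridylmethylamino group at the same place, is reported in this assay as "not active" (no number reported), with no number attached. Going by the values given here, compound 3 `CCCN(CCC)c1nc(C(F)(F)F)ccc1CNC(=O)C(C)c1ccc(NS(C)(=O)=O)c(F)c1`, with dipropylamino at that place, gives 0.2 nM in this assay; the step of a 300-fold lower number from compound 1 to compound 3 (2.47 log units; beyond the scatter) is the single measured change in the set, and it is large.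

Compound 4 `CC(C(=O)NCc1ccc(C(F)(F)F)nc1N1CCC(C(F)(F)F)CC1)c1ccc(NS(C)(=O)=O)c(F)c1` differs from compound 1 in one place: 4-(trifluoromethyl)piperidin-1-yl in place of anilino on an aromatic carbon. Among the compounds with values here, the one measured step that bears on this change is a 300-fold lower number from compound 1 to compound 3 (2.47 log units; beyond the scatter): compound 3 and compound 4 both exchange anilino for a group with one hydrogen-bond acceptor and no hydrogen-bond donor. Compound 2 shows that not every replacement at this place keeps activity, and one supporting step leaves the size open. A large drop in the number is nonetheless expected, a 60-fold lower number from compound 1 to compound 4 (1.78 log units; beyond the scatter), in the direction seen for compound 3. For compound 4 the expected value in this assay is 1 nM, with an estimated range from 0.2 nM to 6 nM.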

Compound 4, inhibition constant: 0.6 nM
Estimate against measurement, compound 4: 1.7-fold (0.22 log units) above; low and high end bracket the measured number.
By their numbers in this assay, from the lowest: compound 3; then compound 4; then compound 1.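

In this assay, the large fall seen with dipropylamino is not unique to that group: 4-(trifluoromethyl)piperidin-1-yl in place of anilino gives a 99-fold lower number from compound 1 to compound 4 (2.00 log units; beyond the scatter), so a non-aromatic ring at this place also reaches the low end of the series, and among the compounds with numbers, the two groups without a hydrogen-bond donor give the lowest values. The two replacements are not interchangeable, however, as 4-(trifluoromethyl)piperidin-1-yl in place of dipropylamino gives a 3.0-fold higher number from compound 3 to compound 4 (0.48 log units; beyond the scatter), a modest step beyond the scatter that is much smaller than either step from anilino. No measurement available here accounts for the size of these steps or for the gap between the two replacements.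

The compounds shown leave open whether the step from anilino follows the loss of the hydrogen-bond donor or the loss of the aromatic ring, a question that an N-methylanilino group at this place would separate. Also open, on these data alone, is what the trifluoromethyl group on the piperidine adds, which could be tested by comparison with plain piperidin-1-yl or with morpholin-4-yl.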